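Lengthening the Chain from Compound 2 to Compound 3

The compounds below may be only part of what the source reports. "The series", "measured", "known", "first", "only" and "open" are said of these compounds alone.

Measured in a functional assay on B16-F10 cells (Mus musculus) for antiproliferative activity, read by MTT assay, with a stated time of 72 h; a higher number here means a weaker inhibitor, a lower number a stronger inhibitor:
- Compound 1 `CCCCCCCCCCNC[C@@H]1OC[C@H](N)[C@@H]1O`: 29600 nM
- Compound 2 `CCCCCCCNC[C@@H]1OC[C@H](N)[C@@H]1O`: > 128000 nM (a limit of the assay)

Compound 2 has no exact number, and its > 128000 nM is only a limit of this assay. Compound 3 `CCCCCCCCCCCNC[C@@H]1OC[C@H](N)[C@@H]1O` differs from it by butyl in place of hydrogen on a saturated chain carbon, seven bonds along the chain from an amine nitrogen: butyl in place of hydrogen on a saturated chain carbon. Within the data shown here, one measured step bears on this change, at the same chain carbon. That step, an at least 4.3-fold higher number from compound 1 to compound 2 (0.63 log units; beyond the scatter), replaces propyl with hydrogen and lies beyond the scatter. Compound 3 makes the opposite kind of change with butyl, so a move to a lower number in this assay is expected, of a size like that measured step or somewhat larger. The expected step is an at least 7.1-fold lower number from compound 2 to compound 3 (0.85 log units; beyond the scatter). Compound 3 is estimated at 18000 nM, with an expected range of 7000 nM to 45000 nM.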

Compound 3, half-maximal inhibitory concentration: 19300 nM
Compound 3: middle estimate off by 1.1-fold (0.03 log units), on the low side; the measured number falls inside the stated range.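

Butyl in place of hydrogen on a saturated chain carbon, seven bonds along the chain from an amine nitrogen, brings an at least 6.6-fold lower number from compound 2 to compound 3 (0.82 log units; beyond the scatter) in this assay and turns an unmeasurable compound into one with a real number. Methyl in place of hydrogen on a saturated chain carbon brings only a 1.5-fold lower number from compound 1 to compound 3 (0.19 log units; within the scatter) in this assay, so this further lengthening shows no clear change, unlike the shortening measured earlier. Compound 2 stands at a limit rather than a number, so its step to the longer chain gives only a minimum size: the limit of > 128000 nM in this assay, at which 1 of the 3 values shown sits.

As far as these compounds go, whether a longer chain, such as dodecyl or tetradecyl, would lower the number further remains open. So does the effect of a phenyl ring or a hydroxyl group on this chain.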